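The compounds below may be only part of what the source reports. "The series", "measured", "known", "first", "only" and "open" are said of these compounds alone.

Measured compounds in a functional assay on HOP-92 cells (Homo sapiens) for inhibition, read by sulforhodamine B assay, with a stated time of 48 h; a higher number here means that more compound is tolerated, a lower number that less compound is tolerated:
- compound 1 `O=C(Nc1cccc(-n2cc(-c3ccncc3)c(-c3ccc(Cl)c(O)c3)n2)c1)Nc1cccc(C(F)(F)F)c1`: compound 1 gives > 32500 nM, a limit of the assay.
- compound 2 `O=C(Nc1cccc(-n2cc(-c3ccncc3)c(-c3ccc(Cl)c(O)c3)n2)c1)Nc1ccc(Cl)c(Cl)c1`: compound 2 gives > 32500 nM, a limit of the assay.
- compound 3 `COc1cc(-c2nn(-c3cccc(NC(=O)Nc4cccc(C(F)(F)F)c4)c3)cc2-c2ccncc2)ccc1Cl`: compound 3 gives > 50000 nM, a limit of the assay.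

For the measured compounds named here, compound 1 stands at a limit in this assay, as do the other two measured compounds; no compound in the set has a readable number. The step from compound 1 to compound 2 is a step that the two limits leave unreadable from compound 1 to compound 2, and the step from compound 1 to compound 3 is a step that the two limits leave unreadable from compound 1 to compound 3, both unreadable because of the limit of > 32500 nM in this assay, at which 2 of the 3 values shown sit, and (the limit of > 50000 nM in this assay, at which 1 of the 3 values shown sits).

Compound 4 `O=C(Nc1cccc(-n2cc(-c3ccncc3)c(-c3ccc(Cl)c(O)c3)n2)c1)Nc1cc(C(F)(F)F)cc(C(F)(F)F)c1` differs from compound 1 by trifluoromethyl in place of hydrogen on an aromatic carbon, on the aryl urea end that was also varied in compound 2. Both measured steps leave the same place unreadable, so no direction can be drawn; the expectation is that compound 4 will again sit at the limit, with a step that the limit leaves unreadable from compound 1 to compound 4 expected to be no readable step beyond the scatter. Compound 4 is therefore estimated at 40000 nM, with a range from 15000 nM to 100000 nM.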

Compound 4, concentration lethal to 50% of the cells: 8660 nM
Beside the measured number, compound 4's estimate is 4.6-fold (0.66 log units) above it, and the stated range ends above it.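

Trifluoromethyl in place of hydrogen on an aromatic carbon, meta to a trifluoromethyl group, gives an at least 3.7-fold lower number from compound 1 to compound 4 (0.57 log units; beyond the scatter) in this assay, the only readable step in the series so far. For the compounds shown here, the other steps cannot be read, so compound 4 is the first sign that a change at the aryl urea end can bring the read-out off the limit, with less compound tolerated. The true size of this step stays unknown because compound 1 stands at a limit: the limit of > 32500 nM in this assay, at which 2 of the 4 values shown sit.

As far as these compounds go, it remains open whether this step is specific to trifluoromethyl or would also follow from another group on the same carbon, such as a nitrile, a methyl or a chlorine. From the compounds shown here alone, it is also open whether methyl on the oxygen, as in compound 3, would keep the number of compound 4.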